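The compounds below may be only part of what the source reports. "The series", "measured", "known", "first", "only" and "open" are said of these compounds alone.

Measured in a toxicity assay on HCT-116 cells (Homo sapiens) for cytotoxicity, read by MTT assay; a lower number here means a stronger inhibitor of growth, a higher number a weaker inhibitor of growth:
Compound 1 `C/C(=N\NC(N)=S)c1sc(-c2ccccc2)nc1C` gives 47.3 ug/mL.
Compound 2 `C/C(=N\Nc1nc(-c2ccccc2)cs1)c1sc(C)nc1C` gives > 100 ug/mL, a limit of the assay rather than a number.
Compound 3 `C/C(=N\Nc1nc(-c2ccccc2)cs1)c1sc(-c2ccccc2)nc1C` gives > 100 ug/mL, likewise a limit of the assay.

Compound 3 therefore sits at the limit of > 100 ug/mL in this assay, at which 2 of the 3 values shown sit, so no number locates it within the series. For the measured compounds named here, the only measured step on its core, a step that the two limits leave unreadable from compound 2 to compound 3, is unreadable for the same reason.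

Compound 4 `C/C(=N\Nc1nc(-c2ccc(Cl)cc2)cs1)c1sc(-c2ccccc2)nc1C` differs from compound 3 by chloro in place of hydrogen on an aromatic carbon. Going by the values given here, no measured step touches this ring, and the one step that exists is unreadable, so nothing points to a direction. Compound 4 is expected to stay at the limit, estimated at 100 ug/mL with a range of 40 ug/mL to 300 ug/mL. The expected step of a number no higher from compound 3 to compound 4 (the limit leaves the size open) is thus none beyond the scatter.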

Compound 4, concentration for 50% growth inhibition: > 100 ug/mL
Compound 4 was reported as a limit; the forecaster's own chance of this, stated with the estimate: 70%; the middle value sits exactly at the limit.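

In this assay compound 3 and compound 4 both stand at a limit of the assay, so no step can be read between them: the limit of > 100 ug/mL in this assay, at which 3 of the 4 values shown sit.
Left open is whether chloro in place of hydrogen on the phenyl ring changes growth inhibition at all on this core.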